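Removing the chloro from compound 2

A few compounds are considered here, and "the series" means these few. Any claim that something is new, unique, unknown or untested is made for them only; others in the source may bear on it.

Measured so far:
compound 1 `OC(CCn1nc2c(Br)c(Br)c(Br)c(Br)c2n1)c1ccc(F)cc1`: 0%
compound 2 `OC(CCn1nc2c(Br)c(Br)c(Br)c(Br)c2n1)c1cccc(Cl)c1`: 0%

In a functional assay on CCRF-CEM cells (Homo sapiens) for antiproliferative activity, read by MTT assay, with a stated time of 48 h, tested at 50 uM (on this read-out lower numbers stand for a stronger effect and higher numbers for a weaker effect at the one concentration tested), compound 1 gives 0% and compound 2 gives 0%, so compound 2 stands level with compound 1; the step was no change at the digits printed from compound 1 to compound 2 (within the scatter). Compound 3 `OC(CCn1nc2c(Br)c(Br)c(Br)c(Br)c2n1)c1ccccc1` is the unmeasured partner, and its difference from compound 2 is hydrogen in place of chloro on an aromatic carbon. Among the compounds with values here, the one measured step swapped a whole aryl group without moving the read-out, so this smaller change on the same ring is expected to leave it in place. For compound 3 the expected step is no change at the digits printed from compound 2 to compound 3 (within the scatter). Compound 3 is estimated at 0%, within 0% to 12%.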

Compound 3, a percentage reported as activity, at one concentration (the size of the read-out at that concentration, not a potency): 0%
Compound 3: middle estimate and measured number agree at the digits printed; measured number inside the range.
By their numbers in this assay, from the lowest: compounds 1, 2 and 3 (each within the scatter of the next).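

In this assay, hydrogen in place of chloro gave no change at the digits printed from compound 2 to compound 3 (within the scatter), and hydrogen in place of fluoro gave no change at the digits printed from compound 1 to compound 3 (within the scatter). The plain phenyl ring therefore reads level with both halogen-bearing rings, so among these compounds neither halogen is needed to hold the read-out at this level. No evidence is available that accounts for the three compounds coinciding. The compounds shown leave open whether an amine or a carboxylic acid on this ring, or a longer chain, would move the read-out away from this shared level.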